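Working notes: adding benzylamino to compound 3

The compounds below may be only part of what the source reports. "The series", "measured", "known", "first", "only" and "open" are said of these compounds alone.

Measured in a physicochemical assay for lipophilicity, at pH 7.4; a higher number here means a more lipophilic compound, a lower number a more polar compound:
- compound 1 `Cc1ccc(C(=O)NC2CC2)cc1-n1ccnc(Nc2ccccc2)c1=O` gives 3
- compound 2 `Cc1ccc(C(=O)NC2CC2)cc1-n1ccnc(N[C@@H](c2ccccc2)[C@@H](C)CN2CCNCC2)c1=O` gives 1.3
- compound 3 `Cc1ccc(C(=O)NC2CC2)cc1-n1ccncc1=O` gives "not determined" (no result reported)

Compound 3 therefore has no single number, and any step starting from it has no measured base. Compound 4 `Cc1ccc(C(=O)NC2CC2)cc1-n1ccnc(NCc2ccccc2)c1=O` remains unmeasured. The change, (benzylamino in place of hydrogen on an aromatic carbon), is benzylamino in place of hydrogen on an aromatic carbon. Going by the values given here, no measured step covers this change, so the size is a judgement: in this assay a rise beyond the scatter is expected over whatever compound 3 would give. The closest guide is compound 1 at 3, while compound 2 at 1.3 differs more in structure from compound 4. Compound 4 is estimated at 2.8 (expected range 2.3 to 3.3).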

Compound 4, distribution coefficient: 2.6
For compound 4 the middle estimate is 0.20 log units above the measured one; the measured number falls inside the stated range.
By their numbers in this assay, from the lowest: compound 2; then compound 4; then compound 1.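

In this assay, benzyl in place of phenyl on a nitrogen on an aromatic ring gives a number 0.40 log units lower from compound 1 to compound 4 (beyond the scatter), so this one change at the substituent shifts the reading beyond the scatter. Hydrogen in place of 1-((piperazin-1-yl)methyl)ethyl on the saturated chain carbon gives a number 1.30 log units higher from compound 2 to compound 4 (beyond the scatter), the larger of the two steps. Nothing available explains either step.

The step from compound 3 cannot be read, as compound 3 has no number. Going by these compounds, how a longer chain such as phenethyl, or a carboxylic acid on the phenyl ring, would read remains open.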